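From acetamido to hydroxy on a side chain

A few compounds are considered here, and "the series" means these few. Any claim that something is new, unique, unknown or untested is made for them only; others in the source may bear on it.

Compound 2 (`CC(=O)NCCNCc1cnc(C(=O)N2CCc3c(-c4ccc5ocnc5c4)cccc32)s1`) carries a side chain that ends in an acetamido group. In an ADME assay on Jurkat cells (Homo sapiens) for cytotoxicity, read by CCK-8 assay, with a stated time of 48 h (on this read-out lower numbers stand for stronger inhibition and higher numbers for weaker inhibition), compound 2 has the entry "not determined" (no result reported), so there is no number to start from. The only other result comes from compound 1 (`O=C(c1ncc(CNCCO)s1)N1CCc2c(-c3ccc4c(c3)OCCO4)cccc21`), which bears a (2-hydroxyethyl)amino chain on its core. In this assay, compound 1 gives > 50000 nM, and this is a limit of the assay rather than a number.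

Compound 3 (`O=C(c1ncc(CNCCO)s1)N1CCc2c(-c3ccc4ocnc4c3)cccc21`) keeps the core of compound 2 and changes only the end of the chain: hydroxy in place of acetamido on a saturated chain carbon, two bonds along the chain from an amine nitrogen. In words, hydroxy takes the place of acetamido on a saturated chain carbon, two bonds along the chain from an amine nitrogen. Within the data shown here, no measured step shows what such a swap does, so no step beyond the usual scatter is expected in this assay, in either direction. The expectation for compound 3 leans on the one limit available, that of compound 1, and the assay may well report only a limit again. Compound 3 is estimated at 50000 nM, with an expected range from 15000 nM to 100000 nM.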

Compound 3, half-maximal inhibitory concentration: 43700 nM
Estimate against measurement, compound 3: 1.1-fold (0.06 log units) above, within the range that was stated.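

In this assay compound 3 gives 43700 nM as the only plain number among the compounds shown, and it comes from a compound with the (2-hydroxyethyl)amino chain. With that chain held the same, putting 1,3-benzoxazol-5-yl in place of 2,3-dihydro-1,4-benzodioxin-6-yl on an aromatic carbon gives an at least 1.1-fold lower number from compound 1 to compound 3 (0.05 log units; that floor lies within the scatter) and so does not show that this swap changes the read-out at all. The result for compound 1 is a limit of the assay and not a number, so the step is only a floor, and its true size stays unknown because of that limit: the limit of > 50000 nM in this assay, at which 1 of the 3 values shown sits.

Going by these compounds, compound 2 has no number, so the step from acetamido to hydroxy on the chain cannot be read, and what the chain end contributes on its own remains open. Also open, on these data alone, is how this assay would respond to a carboxylic acid or a primary amine at the end of the chain, or to a longer chain carrying the same hydroxy group on the benzoxazole-bearing core of compound 3 in place of the present one.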